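Working notes: compound 2 to compound 3

A few compounds are considered here, and "the series" means these few. Any claim that something is new, unique, unknown or untested is made for them only; others in the source may bear on it.

Measured so far in a functional assay on MCF7 cells (Homo sapiens) for inhibition, read by MTT assay, with a stated time of 3 days (on this read-out lower numbers stand for stronger inhibition and higher numbers for weaker inhibition), for two compounds
- compound 1 `COc1cc(-c2nc3ccccc3s2)ccc1OCC(=O)NNC(=O)CN1CCC[C@H]1C(=O)O` gives 840 nM
- compound 2 `CCOC(=O)[C@H](NCC(=O)NNC(=O)COc1ccc(-c2nc3ccccc3s2)cc1OC)[C@@H](C)CC` gives 2900 nM

Compound 2 at 2900 nM holds the higher of the two numbers. Compound 3 `CCOC(=O)[C@H](CS)NCC(=O)NNC(=O)COc1ccc(-c2nc3ccccc3s2)cc1OC` has 1-(ethoxycarbonyl)-2-sulfanylethyl in place of 1-(ethoxycarbonyl)-2-methylbutyl on an amine nitrogen. Within the data shown here, the only measured step (a 3.5-fold higher number from compound 1 to compound 2 (0.54 log units; beyond the scatter)) is modest and beyond the scatter but exchanges a different group, so it bears only loosely. Among the measured compounds shown here, no measured step covers the incoming group. A small change is expected in this assay with the estimated step (a 1.5-fold lower number from compound 2 to compound 3 (0.16 log units; within the scatter)) staying within the scatter and leaning to a lower number. For compound 3 the estimated value is 2000 nM with an expected range from 700 nM to 6000 nM in this read-out.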

Compound 3, half-maximal inhibitory concentration: 2880 nM
Compound 3: the middle estimate sits 1.4-fold (0.16 log units) below what was measured, within the range that was stated.
By their numbers in this assay, from the lowest: compound 1; then compounds 3 and 2 (each within the scatter of the next).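

In this assay, 1-(ethoxycarbonyl)-2-sulfanylethyl and 1-(ethoxycarbonyl)-2-methylbutyl on the amine nitrogen are not told apart (a 1.0-fold lower number from compound 2 to compound 3 (0.00 log units; within the scatter)), so this position accepts the sulfanyl side chain in place of the branched alkyl one. A second ester side chain also stands apart from 2-carboxypyrrolidin-1-yl (a 3.4-fold higher number from compound 1 to compound 3 (0.54 log units; beyond the scatter)), matching the earlier step for compound 2. No evidence on the cause of either result is available.

Whether the carboxylic acid or the ring of compound 1 accounts for this gap remains open. So does the effect of a primary amine or hydroxyl in place of the sulfanyl group.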